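The source may report more compounds than this note shows. Statements on the series, on what has been measured and on what is new or still open speak of the compounds shown alone.

The measured compounds:
Compound 1, `COc1cc(NC(C)CCCNC(=O)NNC(=O)Nc2cccc(F)c2)c2ncccc2c1` — in a functional assay on MOLT-4 cells (Homo sapiens) for inhibition, read by MTT assay, with a stated time of 72 h (a higher number here means a weaker inhibitor, a lower number a stronger inhibitor), compound 1 gives >= 250000 nM, a limit of the assay rather than a number.
Compound 2, `COc1cc(NC(C)CCCNC(=O)Nc2ccc(F)cc2)c2ncccc2c1` — in this assay compound 2 gives 24000 nM.
Compound 3, `COc1cc(NC(C)CCCNC(=O)NNC(=O)Nc2cccc(C(F)(F)F)c2)c2ncccc2c1` — in this assay compound 3 gives 36000 nM.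

Compound 1 therefore stands at the limit of >= 250000 nM in this assay, at which 1 of the 3 values shown sits, and both measured steps run downward from it: an at least 10-fold lower number from compound 1 to compound 2 (1.01 log units; beyond the scatter) and an at least 6.9-fold lower number from compound 1 to compound 3 (0.84 log units; beyond the scatter). Compound 4, `COc1cc(NC(C)CCCNC(=O)NNC(=O)Nc2ccc(O)cc2)c2ncccc2c1`, differs from compound 1 in one place: 4-hydroxyphenyl in place of 3-fluorophenyl on an amide-type nitrogen. The closer precedent is the step to compound 3, which also changes only the group on that aromatic ring and moves the number beyond the scatter; the step to compound 2 reworks the linker as well. The writer thus expects a downward step, an at least 3.1-fold lower number from compound 1 to compound 4 (0.49 log units; beyond the scatter), while allowing that only a limit may again be reported. The estimate for compound 4 is 80000 nM, between 20000 nM and 250000 nM.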

Compound 4, half-maximal inhibitory concentration: 104000 nM
Compound 4: middle estimate off by 1.3-fold (0.11 log units), on the low side, within the range that was stated.
By their numbers in this assay, from the lowest: compounds 2 and 3 (each within the scatter of the next); then compound 4. At a limit, above all of these: compound 1.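

In this assay, 4-hydroxyphenyl on this amide-type nitrogen yields a measured number where 3-fluorophenyl gave none, an at least 2.4-fold lower number from compound 1 to compound 4 (0.38 log units; beyond the scatter); compound 1 stays a limit of the assay, so this step has only a bound: the limit of >= 250000 nM in this assay, at which 1 of the 4 values shown sits. Compared with 3-(trifluoromethyl)phenyl, which gives the first step at this position with numbers at both ends, 4-hydroxyphenyl shows a 2.9-fold higher number from compound 3 to compound 4 (0.46 log units; beyond the scatter). Against the shorter urea, ((4-hydroxyphenyl)carbamoyl)amino in place of 4-fluorophenyl shows a 4.3-fold higher number from compound 2 to compound 4 (0.64 log units; beyond the scatter).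

As far as these compounds go, what 3-hydroxyphenyl or 4-aminophenyl would give on this nitrogen stays open. So does whether the group itself or its place on the ring matters more.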